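Triazole-linked enone series: benzamido to formyl on the phenyl

This account rests on a few compounds, and the source may have more. Where it says the series, first, only, none or still open, it means among the compounds named here.

Working notes. Compound 1 `COc1cc(/C=C/C(C)=O)ccc1OCc1cn(-c2c(F)cccc2F)nn1` gives 24200 nM in a functional assay on PC-3 cells (Homo sapiens) for antiproliferative activity, read by MTT assay, with a stated time of 48 h; a lower number here means a stronger inhibitor, a higher number a weaker inhibitor. Going by the values given here, compound 2 `COc1cccc(-n2cc(COc3ccc(/C=C/C(C)=O)cc3OC)nn2)c1` gives 31600 nM in this assay; the only single-point step among the measured compounds, a 1.3-fold higher number from compound 1 to compound 2 (0.12 log units; within the scatter), is within the scatter. Compound 3 `COc1cc(/C=C/C(C)=O)ccc1OCc1cn(-c2ccc(NC(=O)c3ccccc3)cc2)nn1` gives 76800 nM in this assay, the highest of the three numbers, with its gaps to compound 2 and to compound 1 both beyond the scatter.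

Compound 4 `COc1cc(/C=C/C(C)=O)ccc1OCc1cn(-c2ccc(C=O)cc2)nn1` has not been measured in this assay. It differs from compound 3 by formyl in place of benzamido on an aromatic carbon. Among the compounds with values here, no measured step alters a substituent on this phenyl ring; the one step available, a 1.3-fold higher number from compound 1 to compound 2 (0.12 log units; within the scatter), exchanges the whole aryl group on the aromatic nitrogen and offers no direct guide. Compounds 1 and 2, whose aryl groups on the aromatic nitrogen carry no benzamido, both sit below compound 3, and compound 4 likewise loses the benzamido, so a modest move toward their numbers is expected: step a 1.9-fold lower number from compound 3 to compound 4 (0.28 log units; within the scatter). Compound 4 is therefore estimated at 40000 nM, with a range of 13000 nM to 120000 nM.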

Compound 4, half-maximal inhibitory concentration: 80700 nM
Compound 4: middle estimate off by 2.0-fold (0.30 log units), on the low side; the range from low to high includes it.
By their numbers in this assay, from the lowest: compounds 1 and 2 (each within the scatter of the next); then compounds 3 and 4 (each within the scatter of the next).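

In this assay, formyl in place of benzamido on an aromatic carbon, para to a large group, leaves the number unchanged within the scatter (a 1.1-fold higher number from compound 3 to compound 4 (0.02 log units; within the scatter)), so this position tolerates the much smaller group, with its lost ring and amide hydrogen, without a readable shift. Removing the benzamido does not by itself bring the number toward those of the other aryl groups: the 4-formylphenyl stays apart from the 3-methoxyphenyl (a 2.6-fold higher number from compound 2 to compound 4 (0.41 log units; beyond the scatter)) and from the 2,6-difluorophenyl (a 3.3-fold higher number from compound 1 to compound 4 (0.52 log units; beyond the scatter)), though both steps are modest and also exchange the whole aryl group. No measurement at hand accounts for these steps.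

As far as these compounds go, whether an amine or a carboxylic acid at this position would move the number away from that of compounds 3 and 4 stays open. The compounds shown also leave open whether the unsubstituted phenyl would sit with compounds 1 and 2 or with compounds 3 and 4.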